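The compounds below may be only part of what the source reports. "The series", "measured", "known", "first", "only" and "open" are said of these compounds alone.

In a functional assay on HCT-8 cells (Homo sapiens) (a higher number here means that more compound is needed for the effect, a lower number that less compound is needed), compound 1 `COc1cc2nc(-c3cccc(F)c3)nc(O)c2cc1OC` gives > 20 ug/mL, a limit. Compound 2 `COc1cccc(-c2nc(O)c3ccccc3n2)c1` gives > 20 ug/mL, also a limit. Compound 3 `COc1cccc(-c2nc(O)c3cc(OC)ccc3n2)c1` stands at > 40 ug/mL, again a limit. Compound 4 `COc1cccc(-c2nc(O)c3cc(OC)c(OC)cc3n2)c1` differs from compound 3 by methoxy in place of hydrogen on an aromatic carbon, ortho to a methoxy group. Among the measured compounds shown here, the one measured step of the same kind is a step that the two limits leave unreadable from compound 2 to compound 3. It offers no size to carry over, so no change beyond the scatter is expected in this assay, in either direction. The expected step is a step that the limit leaves unreadable from compound 3 to compound 4. Compound 4 is estimated at 45 ug/mL, with an expected range of 20 ug/mL to 100 ug/mL.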

Compound 4, concentration for half-maximal effect: > 20 ug/mL
Compound 4: a limit, no number (the forecaster's own chance of this, stated with the estimate: 80%); the middle value does not contradict the limit.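

Compound 1, compound 3 and compound 4 each carry a limit, not a number, so the steps from compound 3 and from compound 1 to compound 4 cannot be read. The compounds shown leave open whether methoxy in place of hydrogen or fluoro changes the response at all in this assay.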